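Aryl swaps at the carbonyl: from compound 3 to compound 4

The source may hold more compounds than are shown below. What is called first, only, known or untested is meant among the compounds shown, and "the series" means these compounds.

Compound 3 `COc1cc(-c2nnc3n2NC(c2ccco2)C(C(=O)c2ccc(C(F)(F)F)cc2)S3)cc(OC)c1OC` is one of three analogues of a shared core that differ only in the group on the carbonyl carbon. In a functional assay on HepG2 cells (Homo sapiens) for cytotoxicity, read by MTT assay, with a stated time of 48 h (a higher number here means a weaker inhibitor, a lower number a stronger inhibitor), compound 3 gives a limit, > 100000 nM. Compound 2 `COc1cc(-c2nnc3n2NC(c2ccco2)C(C(=O)C2CC2)S3)cc(OC)c1OC`, carrying cyclopropyl there, likewise gives a limit in this assay of > 100000 nM. Compound 1 `COc1cc(-c2nnc3n2NC(c2ccco2)C(C(=O)c2ccc(F)c(F)c2)S3)cc(OC)c1OC`, carrying 3,4-difluorophenyl, gives a number in this assay, 52400 nM. The steps of an at least 1.9-fold higher number from compound 1 to compound 3 (0.28 log units; that floor lies within the scatter) and an at least 1.9-fold higher number from compound 1 to compound 2 (0.28 log units; that floor lies within the scatter) both run into (the limit of > 100000 nM in this assay, at which 2 of the 3 values shown sit), and the step that the two limits leave unreadable from compound 2 to compound 3 cannot be sized from two limits.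

Compound 4 `COc1cccc(C(=O)C2Sc3nnc(-c4cc(OC)c(OC)c(OC)c4)n3NC2c2ccco2)c1` differs from compound 3 at the same carbonyl carbon: 3-methoxyphenyl in place of 4-(trifluoromethyl)phenyl on a carbonyl carbon. Within the data shown here, the steps that bear on this change are the two exchanges on the carbonyl carbon, each carrying only a floor that lies within the scatter; among the aryl groups one gave a number and one a limit. For compound 4 the expected step is an at least 1.1-fold lower number from compound 3 to compound 4 (0.07 log units; that floor lies within the scatter), small and likely leaving it near the limit again. Compound 4 is estimated in this assay at 85000 nM, within 30000 nM to 200000 nM.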

Compound 4, half-maximal inhibitory concentration: > 100000 nM
Compound 4 gave a limit, no number (the forecaster's own chance of this, stated with the estimate: 55%); middle value at least 1.1-fold (0.07 log units) from the limit.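

Working notes on the carbonyl carbon: in this assay, 3-methoxyphenyl joins 4-(trifluoromethyl)phenyl and cyclopropyl at the limit, so swapping the trifluoromethyl-bearing aryl for one with a methoxy group, which brings a hydrogen-bond acceptor, yields no number: the limit of > 100000 nM in this assay, at which 3 of the 4 values shown sit. Among these compounds, compound 1 remains the only one of the four analogues with a number, and the new comparison with it is an at least 1.9-fold higher number from compound 1 to compound 4 (0.28 log units; that floor lies within the scatter), so this floor alone does not separate the two compounds. The new steps from compound 2 and from compound 3 to compound 4 join two limits and cannot be read.

Going by these compounds, how far the three limit compounds lie from compound 1, or from each other, stays open. Also open, on these data alone, is what a basic amine or carboxylic acid on the aryl ring, or a longer alkyl chain on the carbonyl carbon, would give.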